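The source may report more compounds than this note shows. Statements on the series, on what has been measured and on what is new or still open speak of the compounds shown alone.

Measured compounds in an ADME assay on BaF3 cells (Mus musculus) for cytotoxicity; a lower number here means that less compound is needed, a higher number that more compound is needed for the effect:
- compound 1 `FC(F)(F)Oc1ccc(Nc2cc(-c3cccc4[nH]ccc34)ncn2)cc1`: 3790 nM
- compound 2 `NC(=O)c1cccc(Nc2cc(Nc3ccc(OC(F)(F)F)cc3)ncn2)c1`: > 10000 nM
- compound 3 `NC(=O)Cn1ncc2c(Nc3ccc(OC(F)(F)F)cc3)ncnc21`: 3300 nM

Compound 1 `FC(F)(F)Oc1ccc(Nc2cc(-c3cccc4[nH]ccc34)ncn2)cc1` gives 3790 nM in this assay, the higher of the two plain numbers in hand. Its nearest neighbour is compound 3 `NC(=O)Cn1ncc2c(Nc3ccc(OC(F)(F)F)cc3)ncnc21`, which gives 3300 nM; the two values lie within the scatter of each other, so nothing separates them. For compound 2 `NC(=O)c1cccc(Nc2cc(Nc3ccc(OC(F)(F)F)cc3)ncn2)c1` the assay reports only a limit, > 10000 nM, and not a number; that is the situation described in the limit of > 10000 nM in this assay, at which 1 of the 3 values shown sits.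

The step from compound 1 leads to compound 4 `FC(F)(F)Oc1ccc(Nc2cc(-c3ccnc4[nH]ccc34)ncn2)cc1`, which has not yet been measured. The change is a group of 9 heavy atoms (7 carbon, 2 nitrogen; one five-membered aromatic ring with 1 hetero atom, one six-membered aromatic ring with 1 hetero atom) in place of a group of 9 heavy atoms (8 carbon, 1 nitrogen; one five-membered aromatic ring with 1 hetero atom, one six-membered aromatic ring of carbon only), on an aromatic carbon: the group that leaves and the group that enters have the same number of heavy atoms, and the new group carries one ring nitrogen more, which adds a hydrogen-bond acceptor.

Among the measured compounds shown here, no step between two measured compounds shows what this kind of change does here. The values in hand all sit in a narrow band, so the author expects little movement: the step from compound 1 to compound 4 is expected to stay within the scatter or to shift slightly upward, a 1.2-fold higher number from compound 1 to compound 4 (0.07 log units; within the scatter). Compound 4 is therefore estimated at 4500 nM, with a range from 2000 nM to 10000 nM.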

Compound 4, half-maximal effective concentration: 6850 nM
For compound 4 the middle estimate is 1.5-fold (0.18 log units) below the measured one; low and high end bracket the measured number.
By their numbers in this assay, from the lowest: compounds 3, 1 and 4 (each within the scatter of the next, the first and the last beyond it). At a limit, above all of these: compound 2.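

In this assay, among the compounds shown here, putting the group with one ring nitrogen more in place of 1H-indol-4-yl, on an aromatic carbon of the six-membered aromatic ring with 2 nitrogen, gives a 1.8-fold higher number from compound 1 to compound 4 (0.26 log units; within the scatter), the only step here between two measured compounds that differ in one place. At this position, then, the added ring nitrogen, which brings a hydrogen-bond acceptor while the hydrogen-bond donor stays, does not separate compound 4 from compound 1 in this read-out. Nothing in the data in hand offers a cause for the size of this step.

The compounds shown leave open whether a ring nitrogen elsewhere in the six-membered ring of this group would behave alike, and whether a different group at this place, such as an amine, a carboxylic acid or a plain phenyl ring, would move the number beyond the scatter. They also leave open whether the same exchange would give a similar step on a core other than that of compound 1.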